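Chloro to Methylsulfanyl: What to Expect for Compound 4

The compounds below may be only part of what the source reports. "The series", "measured", "known", "first", "only" and "open" are said of these compounds alone.

Compound 1, `O=C(/C=C/c1ccc2c(c1)B(O)OC2)c1ccco1`, in a toxicity assay on WI-38 cells (Homo sapiens) for cytotoxicity, read by MTT assay, with a stated time of 48 h (a higher number here means a weaker inhibitor, a lower number a stronger inhibitor), compound 1 gives 59000 nM.
Compound 2, `O=C(/C=C/c1ccc2c(c1)B(O)OC2)c1cccs1`, in this assay compound 2 gives 26000 nM.
Compound 3, `O=C(/C=C/c1ccc2c(c1)B(O)OC2)c1ccc(Cl)cc1`, in this assay compound 3 gives 24700 nM.

Among these three, compound 3 has the lowest number, but its gap to compound 2 is within the scatter, so the two cannot be told apart; only compound 1 stands clearly apart, with a 2.4-fold lower number from compound 1 to compound 3 (0.38 log units; beyond the scatter) and a 2.3-fold lower number from compound 1 to compound 2 (0.36 log units; beyond the scatter).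

Compound 4, `CSc1ccc(C(=O)/C=C/c2ccc3c(c2)B(O)OC3)cc1`, differs from compound 3 in one place: methylsulfanyl in place of chloro on an aromatic carbon. The change sits on an aromatic carbon of a six-membered aromatic ring of carbon only, para to a large group.

Within the data shown here, none of the measured steps touches this position. The steps from compound 1 swap the whole group on the carbonyl carbon, and the step of a 1.1-fold lower number from compound 2 to compound 3 (0.02 log units; within the scatter) lies within the scatter. Nothing here tells how a change on the 4-chlorophenyl ring itself moves the number, so no step beyond the scatter is expected in this assay. For compound 4 the estimated value is 25000 nM, in a range from 10000 nM to 60000 nM, which is expected to mean a step of a 1.0-fold higher number from compound 3 to compound 4 (0.01 log units; within the scatter).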

Compound 4, half-maximal inhibitory concentration: 54300 nM
Compound 4: middle estimate off by 2.2-fold (0.34 log units), on the low side, and the stated range covers the measured number.
By their numbers in this assay, from the lowest: compounds 3 and 2 (each within the scatter of the next); then compounds 4 and 1 (each within the scatter of the next).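

Among these compounds, this step is the first to touch the six-membered aromatic ring of carbon only, and it shows that the group para to a large group matters: in this assay, methylsulfanyl in place of chloro gives a 2.2-fold higher number from compound 3 to compound 4 (0.34 log units; beyond the scatter), a modest change but one beyond the scatter. The earlier steps shown here changed the whole group on the carbonyl carbon, whereas here the number moves while the rest of the molecule stays the same. Nothing measured here explains why this swap raises the number, so the shift can only be recorded.

A single swap at this place cannot show a trend, since it is one pair of compounds. On these data alone, it remains open how the number would respond to an amine, a carboxylic acid or a longer chain such as ethylsulfanyl on this same aromatic carbon.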